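This account rests on a few compounds, and the source may have more. Where it says the series, first, only, none or still open, it means among the compounds named here.

Measured in a functional assay on HepG2 cells (Homo sapiens) for antiproliferative activity, read by CCK-8 assay, with a stated time of 48 h; a lower number here means a stronger inhibitor, a higher number a weaker inhibitor:
- Compound 1 `COc1ccc(/C=C\c2cc(OC)c(OC)c(OC)c2)cc1OCc1ccc(CN2C[C@H](O)C[C@@H]2C(=O)O)cc1`: > 10000 nM, which is a limit and not a number
- Compound 2 `COc1ccc(/C=C\c2cc(OC)c(OC)c(OC)c2)cc1OCc1ccc(CNCCO)cc1`: 5900 nM
- Compound 3 `COc1ccc(/C=C\c2cc(OC)c(OC)c(OC)c2)cc1OCc1ccc(CN2CC[C@@H](O)C2)cc1`: 6200 nM

Compound 3 stands level with compound 2, with a 1.1-fold higher number from compound 2 to compound 3 (0.02 log units; within the scatter). Compound 4 `COc1ccc(/C=C\c2cc(OC)c(OC)c(OC)c2)cc1OCc1ccc(CN[C@H](C(=O)O)[C@@H](C)O)cc1` differs from compound 3 at one place: (1-carboxy-2-hydroxypropyl)amino in place of 3-hydroxypyrrolidin-1-yl on a saturated chain carbon bound to an aromatic carbon. The entering group brings a carboxy, which among the measured compounds only compound 1 carries. Going by the values given here, two measured steps bear on this: an at least 1.6-fold lower number from compound 1 to compound 3 (0.20 log units; that floor lies within the scatter), and an at least 1.6-fold lower number from compound 1 to compound 2 (0.22 log units; that floor lies within the scatter). Both start from a limit, so they give only a floor for the size. Read in reverse, they suggest a higher number in this assay, though perhaps not by much more than the scatter. The estimated step is a 1.8-fold higher number from compound 3 to compound 4 (0.25 log units; within the scatter). For compound 4 the expected value is 11000 nM, with an expected range of 5000 nM to 30000 nM.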

Compound 4, half-maximal inhibitory concentration: > 10000 nM
Compound 4: no number, only a limit; the forecaster's own chance of this, stated with the estimate: 55%; the middle value lies beyond the limit too.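

In this assay compound 4 gives > 10000 nM, which is a limit of the assay. With (1-carboxy-2-hydroxypropyl)amino on the saturated chain carbon bound to an aromatic carbon, the steps read an at least 1.6-fold higher number from compound 3 to compound 4 (0.20 log units; that floor lies within the scatter) and an at least 1.6-fold higher number from compound 2 to compound 4 (0.22 log units; that floor lies within the scatter). A carboxy on an open chain therefore ends at the same limit as the carboxy on the ring of compound 1, and both carboxy compounds sit there: the limit of > 10000 nM in this assay, at which 2 of the 4 values shown sit.

On these data alone, the step from compound 1 to compound 4 cannot be read, and how far compound 4 lies past its limit stays open. So does what a methyl ester in place of the carboxy would give.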